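Thiazolylcarbonyl in place of isopropylcarbonyl on the ring amide

The source may report more compounds than this note shows. Statements on the series, on what has been measured and on what is new or still open speak of the compounds shown alone.

Measured so far in an assay on HEK293 cells for agonist activity at Toll-like receptor 8 (Homo sapiens), read by a luciferase reporter, with a stated time of 6 h; on this read-out lower numbers stand for an effect already at smaller amounts and higher numbers for an effect only at larger amounts of compound:
compound 1 `CCCCNc1nc(N)nc2c1CN(Cc1ccncc1)CC2`: 0.29 uM
compound 2 `CCCCNc1nc(N)nc2c1CN(C(=O)C(C)C)CC2`: 1.6 uM

Among the compounds with values here, compound 2 carries the higher of the two numbers in this assay; its nearest neighbour is compound 1, and the only measured step is a 5.5-fold higher number from compound 1 to compound 2 (0.74 log units; beyond the scatter), which replaces the (pyridin-4-yl)methyl on the ring amine by the isopropylcarbonyl and falls beyond the scatter.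

Compound 3 `CCCCNc1nc(N)nc2c1CN(C(=O)c1scnc1C)CC2` keeps the carbonyl on the ring nitrogen of compound 2 and changes only the group on that carbonyl carbon: 4-methyl-1,3-thiazol-5-yl in place of isopropyl on a carbonyl carbon.

The measured step bears on compound 3 only loosely, since it alters both the carbonyl and the aromatic ring at once, whereas here the carbonyl stays and an aromatic ring enters on it. Reading it as the one hint available, compounds with an aromatic ring on the ring nitrogen sit at the lower number, so a moderate decrease is expected rather than none. Compound 3 is therefore estimated at 0.8 uM, with a range of 0.25 uM to 2.5 uM, which corresponds to an expected step of a 2.0-fold lower number from compound 2 to compound 3 (0.30 log units; within the scatter).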

Compound 3, minimum effective concentration: 5.6 uM
The estimate for compound 3 lay 7.0-fold (0.85 log units) below the measured number; the whole stated range lies below it.
By their numbers in this assay, from the lowest: compound 1; then compound 2; then compound 3.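

In this assay, 4-methyl-1,3-thiazol-5-yl in place of isopropyl on a carbonyl carbon gives a 3.5-fold higher number from compound 2 to compound 3 (0.54 log units; beyond the scatter), so with the carbonyl held fixed, the group on it moves the read-out beyond the scatter, and an aromatic ring there does not bring the number down. The wider change, (4-methyl-1,3-thiazol-5-yl)carbonyl in place of (pyridin-4-yl)methyl on an amine nitrogen in a ring, gives a 19-fold higher number from compound 1 to compound 3 (1.29 log units; beyond the scatter), so an aromatic ring as such does not set the level at this position: the two compounds carrying one stand at opposite ends of the order, with the ring-free isopropylcarbonyl of compound 2 in the middle. Nothing at hand accounts for the higher number with the (4-methyl-1,3-thiazol-5-yl)carbonyl group.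

The compounds shown do not separate the part played by the carbonyl from that of the ring in the gap to compound 1. As far as these compounds go, a pyridin-4-yl or a phenyl on the same carbonyl, or a plain butyl directly on the ring nitrogen, would bear on that question, and how any of them would read remains open.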